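Triazolylmethyl spiro-oxindoles: swapping the aryl group on the triazole

A few compounds are considered here, and "the series" means these few. Any claim that something is new, unique, unknown or untested is made for them only; others in the source may bear on it.

Measured compounds in a functional assay on A549 cells (Homo sapiens) for antiproliferative activity, read by MTT assay, with a stated time of 48 h; on this read-out lower numbers stand for stronger inhibition and higher numbers for weaker inhibition:
compound 1, `N#CC1=C(N)Oc2c(c3nc4ccccc4nc3c3ccccc23)C12C(=O)N(Cc1cnnn1-c1ccc(F)cc1)c1ccccc12`: > 50000 nM
compound 2, `CCOc1ccc(-n2nncc2CN2C(=O)C3(C(C#N)=C(N)Oc4c3c3nc5ccccc5nc3c3ccccc43)c3ccccc32)cc1`: 25200 nM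
compound 3, `Cc1ccc(-n2nncc2CN2C(=O)C3(C(C#N)=C(N)Oc4c3c3nc5ccccc5nc3c3ccccc43)c3ccccc32)cc1C`: > 50000 nM

Compound 1 gives only a limit of the assay, > 50000 nM. Compound 3 likewise gives only a limit, > 50000 nM. Within the data shown here, compound 2 is the single compound with an actual number, so it stands alone as the one readable point of the three; the other two sit at the limit of > 50000 nM in this assay, at which 2 of the 3 values shown sit. From compound 1 the step of an at least 1.9-fold lower number from compound 1 to compound 2 (0.29 log units; that floor lies within the scatter) is read against that limit, and so is an at least 1.9-fold higher number from compound 2 to compound 3 (0.29 log units; that floor lies within the scatter).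

The unmeasured compound 4, `Cc1ccc(-n2nncc2CN2C(=O)C3(C(C#N)=C(N)Oc4c3c3nc5ccccc5nc3c3ccccc43)c3ccccc32)cc1Cl`, differs from compound 2 by 3-chloro-4-methylphenyl in place of 4-ethoxyphenyl on an aromatic nitrogen. The step that bears most closely on it is an at least 1.9-fold higher number from compound 2 to compound 3 (0.29 log units; that floor lies within the scatter), where a 3,4-dimethylphenyl took the place of 4-ethoxyphenyl and the number went back to the limit. A 3-chloro-4-methylphenyl is the nearer neighbour of that dimethylphenyl, so compound 4 is expected to move in the same direction, by roughly a 1.8-fold higher number from compound 2 to compound 4 (0.25 log units; within the scatter), with a real chance that the assay again reports only a limit. The estimate for compound 4 in this assay is 45000 nM, within 20000 nM to 120000 nM.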

Compound 4, half-maximal inhibitory concentration: > 50000 nM
Compound 4 was reported as a limit (the forecaster's own chance of this, stated with the estimate: 60%); middle value at least 1.1-fold (0.04 log units) from the limit.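

In this assay, replacing 4-ethoxyphenyl with 3-chloro-4-methylphenyl on the aromatic nitrogen gives an at least 1.9-fold higher number from compound 2 to compound 4 (0.29 log units; that floor lies within the scatter), a step read against a limit, so its full size stays hidden. Among these compounds, compound 2, with its 4-ethoxyphenyl, remains the only one of the four compounds with an actual number, while a third aryl group, in compound 4, gives no readable value. The steps among compounds 1, 3 and 4 cannot be read because all three sit at the same limit: the limit of > 50000 nM in this assay, at which 3 of the 4 values shown sit.

The compounds shown leave open whether the number of compound 2 depends on the ether oxygen or on the ethyl chain, which a methoxy, a propoxy or a dimethylamino group could separate. They also leave open how compounds 1, 3 and 4 rank against one another.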